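The source may hold more compounds than are shown below. What is called first, only, known or untested is meant among the compounds shown, and "the series" means these compounds.

Working notes on the series. Two compounds have been run in a functional assay, read by spectrophotometry, with a stated time of 30 min; a higher number here means a weaker inhibitor, a lower number a stronger inhibitor. Compound 1 `COc1ccc(-c2c3ccc4ccccc4c3nc3c2c(C)nc2c4ccccc4ccc32)cc1` gives 133 ug/mL. Compound 2 `Cc1nc2c3ccccc3ccc2c2nc3c(ccc4ccccc43)c(-c3ccccc3N)c12` gives 95.4 ug/mL. Within the data shown here, the one step between them, a 1.4-fold lower number from compound 1 to compound 2 (0.14 log units; within the scatter), exchanges a 2-aminophenyl for a 4-methoxyphenyl on the shared core; compound 2 and compound 1 thus sit within the scatter of each other, and neither can be called the stronger inhibitor on these two numbers.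

Compound 3 `Cc1nc2c3ccccc3ccc2c2nc3c(ccc4ccccc43)c(-c3ccccc3Cl)c12` is the next member. It differs from compound 2 by chloro in place of amino on an aromatic carbon, on an aromatic carbon of a six-membered aromatic ring of carbon only, ortho to a large group. Among the measured compounds shown here, no measured step in this assay bears on an amino-to-chloro exchange; the only step seen, a 1.4-fold lower number from compound 1 to compound 2 (0.14 log units; within the scatter), changed the whole aryl group and stayed within the scatter. With both measured values close together, no step beyond the scatter is expected, so the estimated move is a 1.0-fold higher number from compound 2 to compound 3 (0.02 log units; within the scatter). Compound 3 is therefore expected to give about 100 ug/mL in this assay, with a range of 45 ug/mL to 230 ug/mL.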

Compound 3, half-maximal inhibitory concentration: 118 ug/mL
Compound 3: middle estimate off by 1.2-fold (0.07 log units), on the low side, and the stated range covers the measured number.
By their numbers in this assay, from the lowest: compounds 2, 3 and 1 (each within the scatter of the next).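

At this position, ortho to a large group, chloro in place of amino gives a 1.2-fold higher number from compound 2 to compound 3 (0.09 log units; within the scatter), so in this assay an exchange that removes the hydrogen-bond donor and acceptor counted for amino stays within the scatter. Comparing the 2-chlorophenyl with the 4-methoxyphenyl gives a 1.1-fold lower number from compound 1 to compound 3 (0.05 log units; within the scatter), so compound 1, compound 2 and compound 3 all lie within the scatter of one another and no order can be drawn among these aryl groups. No supporting data are available to interpret this result.

On these data alone, whether any group at this position can move the number beyond the scatter remains open, for example a carboxylic acid or a hydroxyl. Also open, as far as these compounds go, is whether a change elsewhere on the shared core, such as an ethyl group in place of its methyl, would do so.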